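The source may hold more compounds than are shown below. What is called first, only, known or untested is meant among the compounds shown, and "the series" means these compounds.

Three compounds share one core and differ only in the group carried on the amine side chain. Compound 1 `COc1cc(Oc2cccc(Nc3ccccc3)c2)cc(OC)c1CNCc1ccccc1` gives 5020 nM in a functional assay on HCT-15 cells (Homo sapiens) for inhibition, read by MTT assay, with a stated time of 72 h; a lower number here means a stronger inhibitor, a higher number a weaker inhibitor. Compound 2 `COc1cc(Oc2cccc(Nc3ccccc3)c2)cc(OC)c1CNCc1ccc(F)cc1` gives 3640 nM in this assay, and compound 3 `COc1cc(Oc2cccc(Nc3ccccc3)c2)cc(OC)c1CNCCNC(C)=O` gives 5090 nM. The number for compound 1 is the second highest of the three, nearest to compound 3 and furthest from compound 2, yet both gaps lie within the scatter. The step of a 1.4-fold lower number from compound 1 to compound 2 (0.14 log units; within the scatter) puts a fluoro in place of a hydrogen on an aromatic carbon, and the step of a 1.0-fold higher number from compound 1 to compound 3 (0.01 log units; within the scatter) puts an acetamidomethyl in place of the phenyl, and neither moves beyond the scatter.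

Compound 4 `COc1cc(Oc2cccc(Nc3ccccc3)c2)cc(OC)c1CNCc1ccc(Br)cc1` has not yet been measured. It differs from compound 1 by bromo in place of hydrogen on an aromatic carbon, with the bromo entering para to a large group. The step from compound 1 to compound 2 bears on this most directly, since it places another halogen at the same aromatic carbon, and it stayed within the scatter. The step to compound 4 is therefore expected to be small as well, a 1.3-fold lower number from compound 1 to compound 4 (0.12 log units; within the scatter), in this assay. Compound 4 is estimated at 3800 nM, with a range from 1800 nM to 8000 nM.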

Compound 4, half-maximal inhibitory concentration: 5410 nM
Estimate against measurement, compound 4: 1.4-fold (0.15 log units) below, within the range that was stated.
By their numbers in this assay, from the lowest: compounds 2, 1, 3 and 4 (each within the scatter of the next).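

Bromo on this aromatic carbon, para to a large group, gives a 1.1-fold higher number from compound 1 to compound 4 (0.03 log units; within the scatter) in this assay, so a heavier halogen leaves the number as close to that of the unsubstituted ring as fluoro did. Exchanging one halogen for the other gives a 1.5-fold higher number from compound 2 to compound 4 (0.17 log units; within the scatter) at the same carbon, and swapping the acetamidomethyl group for 4-bromophenyl gives a 1.1-fold higher number from compound 3 to compound 4 (0.03 log units; within the scatter) on the side chain, which means that all four compounds now sit within the scatter of one another, with no listed step going against this. Nothing measured here explains why these changes leave the number in place.

The compounds shown leave open whether any group on this aromatic carbon can move the number beyond the scatter, since hydrogen, fluoro and bromo are the only three seen there, and a nitrile, a carboxylic acid or an amine would be a different kind of test. For the compounds shown here, they also leave open whether a longer chain between the amine nitrogen and the ring would matter, since the benzyl link is the only one seen with these rings.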